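The compounds below may be only part of what the source reports. "The series", "measured", "known", "first", "only" and "open" are said of these compounds alone.

For the measured compounds named here, compound 1, `CN(C)c1ccc(C(=O)Nc2cccc(NC(=O)COc3ccc4c(c3)OCCO4)c2)cc1`, is the first of three compounds measured in an assay on isolated protein for inhibition of Rho-associated protein kinase 2 (Homo sapiens), read by scintillation counting, radiometric assay and 33P incorporation, with a stated time of 40 min, in the presence of a further agent that is not named here; on this read-out lower numbers stand for stronger inhibition and higher numbers for weaker inhibition. In this assay compound 1 reaches only the limit of > 10000 nM, which is a bound of the measurement and not a number. Compound 2, `Cc1c(OCC(=O)Nc2cccc(NC(=O)c3ccc(N(C)C)cc3)c2)ccc2c(=O)ccoc12`, gives 4160 nM in this assay. Compound 3, `CC(=O)Nc1cccc(NC(=O)COc2ccc3c(=O)ccoc3c2)c1`, gives 136 nM in this assay, the lower of the two numbers shown, and its gap to compound 2 lies beyond the usual scatter. Of the three, one value is thus a limit, one is weak and one is strong, and no pair of these compounds differs in a single place, so no measured step can be drawn between them.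

Compound 4, `O=C(COc1ccc2c(=O)ccoc2c1)Nc1cccc(NC(=O)c2ccc(OC(F)(F)F)cc2)c1`, has not yet been measured in this assay. It differs from compound 3 in one place: 4-(trifluoromethoxy)phenyl in place of methyl on a carbonyl carbon. The change leaves the shared core untouched and enlarges the group on the carbonyl carbon. Since compounds 1 and 2 both carry an aryl group at that position and both show weak values, whereas compound 3 with methyl shows the strong one, a weakening is expected, of roughly a 6.6-fold higher number from compound 3 to compound 4 (0.82 log units; beyond the scatter). Compound 4 is therefore estimated at 900 nM, within a range of 150 nM to 5000 nM.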

Compound 4, half-maximal inhibitory concentration: 77 nM
For compound 4 the middle estimate is 12-fold (1.07 log units) above the measured one; the measured number lies below the stated range.
By their numbers in this assay, from the lowest: compounds 4 and 3 (each within the scatter of the next); then compound 2. At a limit, above all of these: compound 1.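

In this assay, replacing the methyl group with 4-(trifluoromethoxy)phenyl gives a 1.8-fold lower number from compound 3 to compound 4 (0.25 log units; within the scatter), so the two compounds do not separate even though the entering group brings 11 heavy atoms and a six-membered aromatic ring where a single carbon stood. For the compounds shown here, an aryl group at this position therefore does not by itself go with a weak value, something the earlier compounds could not show, as compounds 1 and 2 both carry an aryl group there and both read weak. Each of them differs from compound 4 in more than one place, so their weak readings cannot be assigned to any single change.

Compound 1 stands at a limit of the assay and not at a number, so no size can be given for any gap that involves it: the limit of > 10000 nM in this assay, at which 1 of the 4 values shown sits. The compounds shown leave open whether a 4-(dimethylamino)phenyl group on the shared core of compound 3 would read weak, and how this position would respond to a phenyl ring carrying a carboxylic acid or a primary amine, or to a longer alkyl chain in place of methyl.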